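Methyl for ethoxy: one step measured once, unreadable

The source may report more compounds than this note shows. Statements on the series, on what has been measured and on what is new or still open speak of the compounds shown alone.

Measured so far:
Compound 1 `CCOc1cccc2cc(-c3ccc([N+](=O)[O-])cc3)c(=O)oc12`; in an assay on CHO cells for displacement of a labelled ligand from adenosine receptor A3 (Homo sapiens), read by radioligand binding (on this read-out lower numbers stand for stronger inhibition and higher numbers for weaker inhibition), compound 1 gives > 100000 nM, which is a limit of the assay and not a number.
Compound 2 `CCOc1cccc2cc(-c3cc(OC)c(OC)c(OC)c3)c(=O)oc12`; in this assay compound 2 gives 9050 nM.
Compound 3 `Cc1cccc2cc(-c3ccc([N+](=O)[O-])cc3)c(=O)oc12`; in this assay compound 3 gives > 100000 nM, again a limit.

Within the data shown here, compound 2 carries the only number in the set; the other two values sit at the limit of > 100000 nM in this assay, at which 2 of the 3 values shown sit. The change from compound 1 to compound 3 is methyl in place of ethoxy on an aromatic carbon, and its step that the two limits leave unreadable from compound 1 to compound 3 cannot be sized, since both ends are limits. The difference between the cores of compound 1 and compound 2 is not broken down here.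

Compound 4 `COc1cc(-c2cc3cccc(C)c3oc2=O)cc(OC)c1OC` is not yet measured. It repeats the same change on compound 2: methyl in place of ethoxy on an aromatic carbon. The place is the same word for word in both cases, so the two changes are the same change. Among the measured compounds shown here, the one earlier instance gives no readable size, so the expectation for compound 4 can rest only on the value of compound 2, 9050 nM, with no direction taken from compound 3.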

Compound 4, inhibition constant: 9820 nM
Compound 4: the middle estimate sits 1.5-fold (0.18 log units) above what was measured; low and high end bracket the measured number.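

On the core of compound 2, methyl in place of ethoxy on an aromatic carbon gives, in this assay, a 1.1-fold higher number from compound 2 to compound 4 (0.04 log units; within the scatter), so on this core the change leaves no readable mark on the number. Among these compounds, this is one readable pair and shows only that the two groups cannot be told apart on this core in this read-out; it gives no general rule that the change is silent, and a single pair cannot show that a size carries from one core to another. The matching step on the other core cannot be read, as compound 1 and compound 3 each stand at a limit and not at a number, so no comparison between the two cores is possible: the limit of > 100000 nM in this assay, at which 2 of the 4 values shown sit.

Open, on these data alone, is whether the change would also stay within the scatter on a core whose compounds give numbers on both sides of the step. Also open, as far as these compounds go, is what a different group at this place, such as an amine or a longer alkoxy chain, would do to the number on the core of compound 2.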